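This account rests on a few compounds, and the source may have more. Where it says the series, first, only, none or still open, it means among the compounds named here.

In a functional assay on NIH3T3 cells for agonist activity at Urotensin-2 receptor (Homo sapiens), with a stated time of 5 days (a higher number here means that more compound is needed for the effect, a lower number that less compound is needed), compound 1 `CN(C)CCC(NC(=O)C#Cc1ccccc1)c1ccc(Cl)cc1` gives 398 nM. Compound 2 `CN(C)CCC(NC(=O)CCc1ccccc1)c1ccc(Cl)cc1` differs from compound 1 only by phenethyl in place of 2-phenylethynyl on a carbonyl carbon, and in this assay compound 2 gives 1660 nM, so that this change produced a 4.2-fold higher number from compound 1 to compound 2 (0.62 log units; beyond the scatter). Compound 3 `CN(C)CCC(NC(=O)C#Cc1ccccc1)c1ccc2ccccc2c1` carries a different core; how the core of compound 3 differs from the core of compound 1 is not broken down here. In this assay compound 3 gives 457 nM, which sits within the scatter of the value of compound 1. Among the compounds with values here, compound 4 `CN(C)CCC(NC(=O)CCc1ccccc1)c1ccc2ccccc2c1` differs from compound 3 by phenethyl in place of 2-phenylethynyl on a carbonyl carbon, the same change at the same place as the one between compound 1 and compound 2. Because that earlier instance gave a 4.2-fold higher number from compound 1 to compound 2 (0.62 log units; beyond the scatter), a step of similar size is expected, a 4.2-fold higher number from compound 3 to compound 4 (0.62 log units; beyond the scatter). Compound 4 is therefore estimated to give 1900 nM, most likely between 700 nM and 5000 nM.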

Compound 4, half-maximal effective concentration: 603 nM
Estimate against measurement, compound 4: 3.2-fold (0.50 log units) above; the whole stated range lies above it.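

On the core of compound 3, phenethyl in place of 2-phenylethynyl on a carbonyl carbon gave a 1.3-fold higher number from compound 3 to compound 4 (0.12 log units; within the scatter) in this assay. The size of the step therefore did not carry over from one core to the other: the same change on two cores in this assay, a 4.2-fold higher number (0.62 log units; beyond the scatter) from compound 1 to compound 2 and a 1.3-fold higher number (0.12 log units; within the scatter) from compound 3 to compound 4, 3.2-fold (0.50 log units) apart, beyond the scatter of two such steps. This shows that a step measured on one core is a poor guide to its size on the other in this series, but two pairs do not show why the cores differ or how the change would behave on any further core.

From the compounds shown here alone, it remains open whether a styryl group, with a double bond in place of the triple bond, or a longer chain such as phenylpropyl on the carbonyl carbon would follow the pattern of either core.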